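Replacing the nitrile with a phenyl ring on the aryl ether

The source may hold more compounds than are shown below. What is called first, only, known or untested is meant among the compounds shown, and "the series" means these compounds.

Compound 3 `N#Cc1ccc(OCc2cn(Cc3ccccc3)nn2)cc1` holds the lowest of the three numbers measured in an assay on isolated protein for inhibition of Aromatase (Homo sapiens), read by fluorescence and colorimetric assay, with a stated time of 30 min (a lower number here means a stronger inhibitor, a higher number a weaker inhibitor), where compound 3 gives 1360 nM. Among the measured compounds shown here, its nearest neighbour is compound 2 `Clc1ccc(OCc2cn(Cc3ccccc3)nn2)cc1`, which in this assay gives 5040 nM; the only single-change step measured so far, a 3.7-fold lower number from compound 2 to compound 3 (0.57 log units; beyond the scatter), covers the difference between these two. Furthest away is compound 1 `c1ccc(-c2ccc(OCc3cn(C(c4ccccc4)c4ccccc4)nn3)cc2)cc1`, which in this assay gives 15500 nM. Compound 4 `c1ccc(Cn2cc(COc3ccc(-c4ccccc4)cc3)nn2)cc1` has not yet been tested; it differs from compound 3 by phenyl in place of cyano on an aromatic carbon. For the measured compounds named here, no measured step exchanges a nitrile for a phenyl ring, so the step of compound 2 to compound 3 speaks only to the sensitivity of this position, not to the direction of the new change. Compound 1, which carries the same phenyl group together with a different group on the triazole nitrogen, shows the weakest number of the set. On that basis compound 4 is expected to weaken, with an estimated step of a 4.4-fold higher number from compound 3 to compound 4 (0.64 log units; beyond the scatter). Compound 4 is therefore estimated at 6000 nM, within a range from 1800 nM to 20000 nM.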

Compound 4, half-maximal inhibitory concentration: 10700 nM
Compound 4: the middle estimate sits 1.8-fold (0.25 log units) below what was measured, within the range that was stated.
By their numbers in this assay, from the lowest: compound 3; then compound 2; then compounds 4 and 1 (each within the scatter of the next).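

In this assay, among the compounds shown here, the first direct exchange of nitrile for phenyl on this aromatic carbon, para to a large group, gives a 7.9-fold higher number from compound 3 to compound 4 (0.90 log units; beyond the scatter) and so goes toward weaker inhibition, while the phenyl also falls behind chloro, with a 2.1-fold higher number from compound 2 to compound 4 (0.33 log units; beyond the scatter) ( beyond the scatter, though only just ). The step of a 1.4-fold lower number from compound 1 to compound 4 (0.16 log units; within the scatter), hydrogen in place of phenyl on the saturated chain carbon, leaves the two values level, so the high number of compound 1 is matched without that second phenyl. Nothing available explains why phenyl and nitrile differ at this position.

As far as these compounds go, whether an amine, a carboxylic acid or a methoxy group on this carbon would land nearer compound 3 or compound 4 stays open. Also open, from the compounds shown here alone, is whether the nitrile would keep its lower number with the group that compound 1 carries on its saturated chain carbon.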